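A few compounds are considered here, and "the series" means these few. Any claim that something is new, unique, unknown or untested is made for them only; others in the source may bear on it.

Working notes on the series. Compound 1 `COc1cc(OC2CCC2)cc(-c2ccc3c(c2)CC[C@H]([C@@H]2C[C@H]2C(=O)O)O3)c1F` is measured in a functional assay on HEK293 cells for agonist activity at Free fatty acid receptor 1 (Homo sapiens), read by HTRF and inositol phosphate accumulation, with a stated time of 60 min (on this read-out higher numbers stand for an effect only at larger amounts of compound and lower numbers for an effect already at smaller amounts), where compound 1 gives > 10000 nM, a limit of the assay rather than a number. Compound 2 `O=C(O)CC[C@@H]1CCc2cc(-c3cc(OC(F)(F)F)ccc3F)ccc2O1` gives > 10000 nM in this assay, again a limit. Compound 3 `CO[C@H]1C[C@H](Oc2cc(F)c(F)c(-c3ccc4c(c3)CC[C@H]([C@@H]3C[C@H]3C(=O)O)O4)c2)C1` gives > 10000 nM in this assay, also a limit. Compound 1 thus stands nowhere apart from the others, since (the limit of > 10000 nM in this assay, at which 3 of the 3 values shown sit). The unmeasured compound 4 `COc1cc(OC2CCC2)cc(-c2ccc3c(c2)CC[C@H](CCC(=O)O)O3)c1F` differs from compound 1 in one place: 2-carboxyethyl in place of 2-carboxycyclopropyl on a saturated ring carbon. Compound 2 already carries 2-carboxyethyl on the shared core and sits at the same limit. No step beyond the scatter is expected in this assay; the estimated step is a step that the limit leaves unreadable from compound 1 to compound 4. Compound 4 is expected at 15000 nM, with a range from 3000 nM to 60000 nM, and most likely only a limit will again be reported.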

Compound 4, half-maximal effective concentration: > 10000 nM
Compound 4 was reported as a limit (the forecaster's own chance of this, stated with the estimate: 75%); the middle value does not contradict the limit.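

No step can be read between compound 1 and compound 4, because both results are limits: the limit of > 10000 nM in this assay, at which 4 of the 4 values shown sit.

The compounds shown leave open how 2-carboxyethyl and 2-carboxycyclopropyl compare on the shared core, since none gives a value that is not a limit.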